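A few compounds are considered here, and "the series" means these few. Any claim that something is new, unique, unknown or untested is made for them only; others in the source may bear on it.

Of the compounds shown here, two have a measured value so far in a physicochemical assay for solubility, in simulated intestinal fluid, with a stated time of 5 h, at pH 5.8; a lower number here means a less soluble compound, a higher number a more soluble compound. Compound 1 (`Cc1cc(Nc2ccc(S(F)(F)(F)(F)F)cc2)n2nc(C(F)(F)F)nc2n1`) gives 27.6 ug/mL. Compound 2 (`Cc1c(Cc2ccc(C(F)(F)F)nc2)c[nH]c1C(=O)NC(C)c1cnn(C)c1`) gives 158 ug/mL, the higher of the two numbers and beyond the scatter of compound 1. These two compounds do not differ in just one place, so the gap cannot be tied to any single group. Compound 3 (`Cc1c(Cc2ccc(C(F)(F)F)nc2)c[nH]c1C(=O)NC(C)c1cn[nH]c1`), not yet measured, departs from compound 2 in one place: hydrogen in place of methyl on an aromatic nitrogen, turning 1-methyl-1H-pyrazol-4-yl into 1H-pyrazol-4-yl. Going by the values given here, no measured pair shows this change, so the expectation starts from compound 2 at 158 ug/mL alone. In this assay, a small downward step within the scatter is expected. The estimated change is a 1.3-fold lower number from compound 2 to compound 3 (0.10 log units; within the scatter). For compound 3, the expected value is 125 ug/mL, with an estimated range of 50 ug/mL to 300 ug/mL.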

Compound 3, solubility: 81 ug/mL
Estimate against measurement, compound 3: 1.5-fold (0.19 log units) above; low and high end bracket the measured number.
By their numbers in this assay, from the lowest: compound 1; then compounds 3 and 2 (each within the scatter of the next).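

Hydrogen in place of methyl on the aromatic nitrogen, turning 1-methyl-1H-pyrazol-4-yl into 1H-pyrazol-4-yl, gives a 2.0-fold lower number from compound 2 to compound 3 (0.29 log units; within the scatter) in this assay. Going by these compounds alone, this is the only pair so far that differs in one place, and it shows that at this nitrogen the measurement does not separate methyl from hydrogen, although the step lies close to the edge of the scatter. No supporting measurement bears on this step, so the result stays without an explanation.

From the compounds shown here alone, whether an ethyl group, a longer chain or a chain carrying an amine or a carboxylic acid on this nitrogen would give a step beyond the scatter remains open, since a single pair sets no trend at this position. Within the data shown here, compound 1 is still joined to the others by no one-place step, so nothing can be read from it about any single group.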